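This account rests on a few compounds, and the source may have more. Where it says the series, first, only, none or still open, it means among the compounds named here.

Of the compounds shown here, three built on one shared core have been tested in an ADME assay on PC-3 cells (Homo sapiens) for cytotoxicity, read by WST assay, tested at 100 uM; on this read-out lower numbers stand for less inhibition and higher numbers for more inhibition at the one concentration tested (going by the name of the read-out). Compound 1 `O=C(Nc1cccc(N2CCCC2=O)c1)C1CCCN(C(=O)c2cc(C(F)(F)F)cc(C(F)(F)F)c2)C1` gives 0%. Compound 2 `O=C(Nc1cccc(Oc2ccccc2)c1)C1CCCN(C(=O)c2cccc(-c3ccco3)c2)C1` gives 0%. Compound 3 `O=C(Nc1cccc(Oc2ccccc2)c1)C1CCCN(C(=O)c2cc(C(F)(F)F)cc(C(F)(F)F)c2)C1` gives 1%, the highest of the three numbers, yet its gap to compound 1 and its gap to compound 2 both lie within the scatter, so the three stand together at the low end of the read-out.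

Among the measured compounds shown here, the one measured step that touches the same part of the molecule is a number 1 percentage points higher from compound 1 to compound 3 (within the scatter), a swap on an aromatic carbon of a six-membered aromatic ring of carbon only that did nothing beyond the scatter.

Compound 4 `O=C(Nc1cccc(-c2cnco2)c1)C1CCCN(C(=O)c2cc(C(F)(F)F)cc(C(F)(F)F)c2)C1` differs from compound 3 in one place: 1,3-oxazol-5-yl in place of phenoxy on an aromatic carbon. Since the comparable step stayed within the scatter and all three measured numbers sit close together, no step beyond the scatter is expected in this assay. The step expected for compound 4 is a number 1 percentage points higher from compound 3 to compound 4 (within the scatter). Compound 4 is estimated at 2%, with a range from 0% to 12%.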

Compound 4, a percentage reported as inhibition, at one concentration (the size of the read-out at that concentration, not a potency): 9%
The estimate for compound 4 lay 7 percentage points below the measured number, within the range that was stated.
By their numbers in this assay, from the lowest: compounds 1, 2, 3 and 4 (each within the scatter of the next).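

On the aromatic carbon where the three groups have been swapped, 1,3-oxazol-5-yl is a third kind of group, and this assay gives two new steps (a number 8 percentage points higher from compound 3 to compound 4 (within the scatter)) and (a number 9 percentage points higher from compound 1 to compound 4 (within the scatter)). Both lie within the scatter, so this read-out does not separate 1,3-oxazol-5-yl from phenoxy or from 2-oxopyrrolidin-1-yl, even though its five-membered aromatic ring with 2 hetero atoms differs from the six-membered ring of phenoxy. Nothing measured here explains the number for compound 4.

Going by these compounds, whether a different kind of group at this place, such as an amine or a carboxylic acid, would give a step beyond the scatter remains open. So does whether this swap would read the same with other groups in place of the two trifluoromethyl groups.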